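Amide nitrogen substituent series on the shared core

This account rests on a few compounds, and the source may have more. Where it says the series, first, only, none or still open, it means among the compounds named here.

Measured so far:
compound 1 `Cc1ccc(OCC(=O)N(Cc2cccs2)CC(C)C)cc1` — 900 nM
compound 2 `Cc1ccc(OCC(=O)N(CCCO)Cc2cccs2)cc1` — 3000 nM

Among the compounds with values here, compound 2 holds the highest number of the two measured in an assay on HEK293 cells for agonist activity at transient receptor potential cation channel subfamily M member 8 (Homo sapiens), read by fluorescence and calcium flux, with a stated time of 15 min; on this read-out higher numbers stand for an effect only at larger amounts of compound and lower numbers for an effect already at smaller amounts; compound 1 is its only neighbour, and the gap is a 3.3-fold higher number from compound 1 to compound 2 (0.52 log units; beyond the scatter), which is beyond the scatter. Nothing beyond this single comparison is available for the amide nitrogen substituent.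

Compound 3 `Cc1ccc(OCC(=O)N(Cc2cccs2)c2ccon2)cc1` is not yet measured. It differs from compound 2 as follows: 1,2-oxazol-3-yl in place of 3-hydroxypropyl on an amide-type nitrogen. Within the data shown here, the only step that bears on this change is the one from compound 1 to compound 2, where the hydrogen-bond donor chain entered and the number rose by a 3.3-fold higher number from compound 1 to compound 2 (0.52 log units; beyond the scatter). Compound 3 removes that donor chain again and puts a ring in its place; the direction is therefore expected to reverse, while the size is uncertain since no aromatic substituent on the amide nitrogen has been measured.

For compound 3 a step of a 2.5-fold lower number from compound 2 to compound 3 (0.40 log units; beyond the scatter) in this assay is expected. The estimate for compound 3 is 1200 nM, with a range from 400 nM to 4000 nM.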

Compound 3, half-maximal effective concentration: 2 nM
The estimate for compound 3 lay 600-fold (2.78 log units) above the measured number, outside the stated range (below it).
By their numbers in this assay, from the lowest: compound 3; then compound 1; then compound 2.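

In this assay the substituent on the amide-type nitrogen turns out to govern the number far more strongly than the two saturated chains suggested: 1,2-oxazol-3-yl in place of 3-hydroxypropyl gives a 1500-fold lower number from compound 2 to compound 3 (3.18 log units; beyond the scatter) and dwarfs the earlier 3.3-fold higher number from compound 1 to compound 2 (0.52 log units; beyond the scatter) seen between the chains. The comparison with the isobutyl compound gives a 450-fold lower number from compound 1 to compound 3 (2.65 log units; beyond the scatter) and shows that removing the hydroxyl cannot be the whole story, since compound 1 carries no hydroxyl either and still lies far from compound 3; what separates compound 3 from both chains is the five-membered aromatic ring with its 2 hetero atoms, directly on the amide-type nitrogen. Nothing at hand gives a measured reason for a change of this size.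

As far as these compounds go, with a single ring at this position, it remains open whether any aromatic ring suffices or whether the hetero atoms of the 1,2-oxazol-3-yl group matter, and a plain phenyl ring or a pyridin-2-yl ring in the same place would separate the two. Also open, from the compounds shown here alone, is whether the ring must sit directly on the nitrogen, a question that a 1,2-oxazol-3-ylmethyl group would address.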